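Working notes: pentyl to 4,4-difluorocyclohexyl in compound 3

A few compounds are considered here, and "the series" means these few. Any claim that something is new, unique, unknown or untested is made for them only; others in the source may bear on it.

compound 1 `C=C1C(=O)O[C@H]2CC3=C[C@H](C/C(C)=C/[C@@H](OC(=O)/C=C/c4cccc(OC)c4)[C@H]12)OC3=O` gives 6200 nM in a functional assay on A549 cells (Homo sapiens) for cytotoxicity, read by MTT assay, with a stated time of 48 h; on this read-out higher numbers stand for weaker inhibition and lower numbers for stronger inhibition
compound 2 `C=C1C(=O)O[C@H]2CC3=C[C@H](C/C(C)=C/[C@@H](OC(=O)CCCCBr)[C@H]12)OC3=O` gives > 10000 nM as a limit
compound 3 `C=C1C(=O)O[C@H]2CC3=C[C@H](C/C(C)=C/[C@@H](OC(=O)CCCCC)[C@H]12)OC3=O` gives > 10000 nM as a limit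

Compound 3 has no number, and its entry > 10000 nM is only a limit. That entry is the limit of > 10000 nM in this assay, at which 2 of the 3 values shown sit, and so gives no exact position.

Compound 4 `C=C1C(=O)O[C@H]2CC3=C[C@H](C/C(C)=C/[C@@H](OC(=O)C4CCC(F)(F)CC4)[C@H]12)OC3=O` differs from compound 3 in one group. The change is 4,4-difluorocyclohexyl in place of pentyl on a carbonyl carbon and in short reads 4,4-difluorocyclohexyl in place of pentyl on a carbonyl carbon.

Among the compounds with values here, no measured step makes this exchange. The nearest evidence is an at least 1.6-fold higher number from compound 1 to compound 3 (0.20 log units; that floor lies within the scatter) and an at least 1.6-fold higher number from compound 1 to compound 2 (0.20 log units; that floor lies within the scatter) with both floors within the scatter, while a step that the two limits leave unreadable from compound 2 to compound 3 cannot be sized. Within the data shown here, compound 1, with 2-(3-methoxyphenyl)ethenyl, is the only compound with a number. Compound 4 also lacks that group, so in this assay no step beyond the scatter is expected, and another limit is the likeliest report.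

The expected step is a step that the limit leaves unreadable from compound 3 to compound 4 and it remains an estimate. For compound 4 the estimated value is 12000 nM with an expected range from 5000 nM to 30000 nM overall.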

Compound 4, half-maximal inhibitory concentration: 6400 nM
The estimate for compound 4 lay 1.9-fold (0.27 log units) above the measured number, within the range that was stated.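

In this assay compound 4 gives 6400 nM, so on this carbonyl carbon a measured number no longer depends on the 2-(3-methoxyphenyl)ethenyl group of compound 1; a saturated six-membered ring carrying two fluorines also gives one. The comparison with that group shows a 1.0-fold higher number from compound 1 to compound 4 (0.01 log units; within the scatter), so the two groups cannot be told apart in this assay. Against the open chains only floors can be given, an at least 1.5-fold lower number from compound 3 to compound 4 (0.19 log units; that floor lies within the scatter) and an at least 1.5-fold lower number from compound 2 to compound 4 (0.19 log units; that floor lies within the scatter), so no gain beyond the scatter can be claimed for the ring over pentyl or 4-bromobutyl, and the true size of both steps stays unknown: the limit of > 10000 nM in this assay, at which 2 of the 4 values shown sit.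

The compounds shown do not separate the contribution of the ring from that of the two fluorines, a question that plain cyclohexyl on the same carbonyl carbon would address. As far as these compounds go, it also remains open whether a ring bearing an amine or a carboxylic acid, or a phenyl group placed directly on this carbonyl carbon, would give a number clearly beyond the scatter from those of compound 1 and compound 4.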